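The source may report more compounds than this note shows. Statements on the series, on what has been measured and on what is new or still open speak of the compounds shown alone.

Compound 3 `CCS(=O)(=O)N(Cc1cccnc1)c1cccc(Oc2ccccc2)c1` gives 360 nM in an assay on isolated protein with metabotropic glutamate receptor 2 (Homo sapiens) as the target; a higher number here means that more compound is needed for the effect, a lower number that less compound is needed. Among the three measured compounds it gives the highest number, though its place is narrow: compound 1 `CCS(=O)(=O)N(Cc1cccnc1)c1cccc(Cc2ccccc2)c1` gives 310 nM, and the step of a 1.2-fold higher number from compound 1 to compound 3 (0.06 log units; within the scatter) stays within the scatter, while compound 2 `CCS(=O)(=O)N(Cc1cccnc1)c1cccc(COc2ccccc2)c1` gives 160 nM, and only the step of a 2.3-fold higher number from compound 2 to compound 3 (0.35 log units; beyond the scatter) goes beyond it. Compound 4 `CCS(=O)(=O)N(Cc1cccnc1)c1cccc(OC(F)(F)F)c1` differs from compound 3 by trifluoromethyl in place of phenyl on an oxygen on an aromatic ring. Among the compounds with values here, no measured step exchanges an aromatic ring for a group without a ring; the steps that touch this part of the molecule, a 1.9-fold lower number from compound 1 to compound 2 (0.29 log units; within the scatter) and a 2.3-fold higher number from compound 2 to compound 3 (0.35 log units; beyond the scatter), are both small, so changes here have so far moved the number little. Removing the ring altogether is a larger change than any of these, so a modest rise in the number is expected, estimated as a 1.4-fold higher number from compound 3 to compound 4 (0.14 log units; within the scatter). Compound 4 is therefore estimated at 500 nM, with a range from 150 nM to 1500 nM.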

Compound 4, half-maximal effective concentration: 1600 nM
Estimate against measurement, compound 4: 3.2-fold (0.51 log units) below; the whole stated range lies below it.
By their numbers in this assay, from the lowest: compounds 2, 1 and 3 (each within the scatter of the next, the first and the last beyond it); then compound 4.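

In this assay, within the data shown here, this is the first change at this position to move the number by more than a small amount: with the phenyl ring gone, a 4.4-fold higher number from compound 3 to compound 4 (0.65 log units; beyond the scatter) exceeds every step among the ring-bearing compounds. The other two comparisons point the same way, with a 10-fold higher number from compound 2 to compound 4 (1.00 log units; beyond the scatter) and a 5.2-fold higher number from compound 1 to compound 4 (0.71 log units; beyond the scatter), so all three compounds that end in a phenyl ring give lower numbers than the trifluoromethoxy compound. Changing the link to that ring has moved the number far less than losing the ring, at least across these four compounds.

No evidence is available that explains this rise. The compounds shown leave open whether an aromatic ring is needed or any ring would do, and a cyclohexyl group or a pyridine ring on the same oxygen would bear on that, as would a plain methyl group on whether the fluorines matter.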